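A few compounds are considered here, and "the series" means these few. Any claim that something is new, unique, unknown or untested is made for them only; others in the source may bear on it.

Compound 1 `CSc1ccc(C(=O)/C(=C/c2cc3ccccc3s2)c2ccc(Cl)c(Cl)c2)cc1`; in an ADME assay on Vero cells (Chlorocebus sabaeus) for cytotoxicity, read by MTT assay, tested at 50 uM (a higher number here means a weaker effect of the compound at the concentration tested, a lower number a stronger effect), compound 1 gives 91.6%. Compound 2 `CSc1ccc(C(=O)/C(=C/c2cccnc2)c2ccc(Cl)c(Cl)c2)cc1`; in this assay compound 2 gives 89.6%. Compound 3 `CCOC(=O)C(C(=O)c1ccc(OC)cc1)C(NC(C)=O)c1ccc(C(C)C)cc1`; in this assay compound 3 gives 96.5%.

Among the compounds with values here, of these three numbers, the one for compound 3 is the highest, though its gaps to compound 1 and to compound 2 both lie within the scatter, so all three compounds stand together near the top of the scale. Within the data shown here, the only measured step, a number 2 percentage points lower from compound 1 to compound 2 (within the scatter), concerns a different change on a different core from the one compound 3 carries, and it too stays within the scatter.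

Compound 4 `CCOC(=O)C(C(=O)c1ccc(OC)cc1)C(NC(C)=O)c1ccc(C(C)(C)C)cc1` differs from compound 3 by methyl in place of hydrogen on a saturated chain carbon bound to an aromatic carbon and two saturated chain carbons. Among the measured compounds shown here, no measured step covers this change, and the one step that exists shows no movement beyond the scatter. The expectation for this assay is therefore a step of a number 1.5 percentage points lower from compound 3 to compound 4 (within the scatter), that is none beyond the scatter. Compound 4 is estimated at 95%, with a range from 85% to 100%.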

Compound 4, a percentage reported as activity, at one concentration (the size of the read-out at that concentration, not a potency): 92.3%
Compound 4: middle estimate off by 2.7 percentage points, on the high side; low and high end bracket the measured number.
By their numbers in this assay, from the lowest: compounds 2, 1, 4 and 3 (each within the scatter of the next).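

Within the data shown here, the change from 4-isopropylphenyl to 4-(tert-butyl)phenyl provides the first measured step at this position: in this assay the result is a number 4.2 percentage points lower from compound 3 to compound 4 (within the scatter) and so, with methyl in place of hydrogen on this saturated chain carbon, the number does not move beyond the scatter. Together with the step on the core of compound 1, this shows a change on a second core that also stays within the scatter. No evidence is available that bears on this result.

As far as these compounds go, it remains open whether an amine or a carboxylic acid in place of the tert-butyl group, or a longer chain there, would take the number beyond the scatter. Also open, from the compounds shown here alone, is whether the same change would stay within the scatter on the core of compound 1.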